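The compounds below may be only part of what the source reports. "The series", "measured", "known", "first", "only" and "open" are said of these compounds alone.

Measured so far in a functional assay on HepG2 cells (Homo sapiens) for antiproliferative activity, read by MTT assay; a higher number here means a weaker inhibitor, a lower number a stronger inhibitor:
compound 1 `O=C1N=C(N2CCC[C@H]2C(=O)Nc2ccc3ncnc(Nc4cccc(Cl)c4)c3c2)S/C1=C/c1ccc(Br)s1` — > 50000 nM (a limit of the assay, not a number)
compound 2 `Cc1cccc(/C=C2/SC(N3CCC[C@H]3C(=O)Nc3ccc4ncnc(Nc5cccc(Cl)c5)c4c3)=NC2=O)n1` — 4500 nM
compound 3 `O=C1N=C(N2CCC[C@H]2C(=O)Nc2ccc3ncnc(Nc4cccc(Cl)c4)c3c2)S/C1=C/c1cccs1` — 4120 nM

Compound 3 gives the lowest of the two numbers; compound 2 sits nearest, with a 1.1-fold lower number from compound 2 to compound 3 (0.04 log units; within the scatter), so the two cannot be told apart. Compound 1 is a limit, as noted by the limit of > 50000 nM in this assay, at which 1 of the 3 values shown sits.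

Compound 4 `O=C1N=C(N2CCC[C@H]2C(=O)Nc2ccc3ncnc(Nc4cccc(Cl)c4)c3c2)S/C1=C/c1cccnc1Cl` is the next step from compound 3. The change: 2-chloropyridin-3-yl in place of thiophen-2-yl on a double-bonded chain carbon bound to a double-bonded ring carbon.

Two measured steps change the same position. an at least 11-fold lower number from compound 1 to compound 2 (1.04 log units; beyond the scatter) and a 1.1-fold lower number from compound 2 to compound 3 (0.04 log units; within the scatter) show that exchanging the aryl group at the double-bonded chain carbon can move this assay a great deal or not at all; an at least 12-fold lower number from compound 1 to compound 3 (1.08 log units; beyond the scatter) shows that a bromo on that aryl goes with the limit. Compound 4 carries a six-membered ring with a chlorine, which none of the numbered compounds has, so the outcome is open; a somewhat weaker result than compound 3 is expected, with the possibility of a limit kept in mind. For compound 4 the step from compound 3 is estimated as a 2.2-fold higher number from compound 3 to compound 4 (0.34 log units; beyond the scatter). Compound 4 is expected to give about 9000 nM, within a range of 2500 nM to 40000 nM.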

Compound 4, half-maximal inhibitory concentration: 6400 nM
The estimate for compound 4 lay 1.4-fold (0.15 log units) above the measured number, within the range that was stated.
By their numbers in this assay, from the lowest: compounds 3, 2 and 4 (each within the scatter of the next). At a limit, above all of these: compound 1.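

In this assay, the six-membered 2-chloropyridin-3-yl cannot be told apart from either the five-membered thiophen-2-yl or the 6-methylpyridin-2-yl at this position: a 1.6-fold higher number from compound 3 to compound 4 (0.19 log units; within the scatter) and a 1.4-fold higher number from compound 2 to compound 4 (0.15 log units; within the scatter). A halogen on the aryl group therefore does not by itself go with the loss seen for compound 1, as compound 4 carries a chlorine and still gives a measurable number, with an at least 7.8-fold lower number from compound 1 to compound 4 (0.89 log units; beyond the scatter). Compound 1 remains the only compound at a limit of the assay, and its value is not a number: the limit of > 50000 nM in this assay, at which 1 of the 4 values shown sits.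

The compounds shown do not separate the effect of the halogen from that of the ring carrying it, since the bromo sits only on a thiophene and the chlorine only on a pyridine; a chloro-substituted thiophen-2-yl or a bromo-substituted pyridin-3-yl would divide the two. As far as these compounds go, it also remains open whether any group on the double-bonded chain carbon can give a clearly lower number than these three aryl groups, for instance an aryl ring carrying an amine or a carboxylic acid.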